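A few compounds are considered here, and "the series" means these few. Any claim that something is new, unique, unknown or untested is made for them only; others in the source may bear on it.

Compound 1 `Fc1ccccc1[C@H](Nc1nnc(-c2c[nH]c3ncccc23)o1)C1CC1`: 35%
Compound 2 `Fc1ncccc1[C@H](Nc1nnc(-c2c[nH]c3ncccc23)o1)C1CC1`: 41%

Within the data shown here, in an ADME assay on the whole organism for pharmacokinetics, with Rattus norvegicus as the target (a higher number here means that a larger share of the oral dose reaches the circulation, a lower number that a smaller share of the oral dose reaches the circulation), compound 2 gives 41%, within the scatter of compound 1, the only other compound measured. Compound 3 `Fc1cnc2[nH]cc(-c3nnc(N[C@@H](c4cccnc4F)C4CC4)o3)c2c1` has fluoro in place of hydrogen on an aromatic carbon. Among the measured compounds shown here, the only measured step, a number 6 percentage points higher from compound 1 to compound 2 (within the scatter), lies elsewhere in the structure, so it bears only weakly on this change and gives no direction. No step beyond the scatter is therefore expected, and the expected step is a number 1 percentage points lower from compound 2 to compound 3 (within the scatter). The estimate for compound 3 is 40%, with an expected range of 24% to 56%.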

Compound 3, oral bioavailability: 50%
Estimate against measurement, compound 3: 10 percentage points below, and the stated range covers the measured number.
By their numbers in this assay, from the lowest: compounds 1, 2 and 3 (each within the scatter of the next, the first and the last beyond it).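

In this assay, fluoro in place of hydrogen on the aromatic carbon two atoms from the ring nitrogen comes with a number 9 percentage points higher from compound 2 to compound 3 (within the scatter). Among these compounds, this is the first reading at this position, and it shows that the carbon accepts fluoro with no change beyond the scatter. Nothing available bears on a cause for this step.

As far as these compounds go, whether chloro, methoxy or a nitrile on this carbon would move the number beyond the scatter remains open. Also open, from the compounds shown here alone, is whether fluoro here would read the same with 2-fluorophenyl on the chain carbon.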